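Aryl swap on the shared core: pyridyl in place of fluorophenyl

The compounds below may be only part of what the source reports. "The series", "measured", "known", "first", "only" and "open" are said of these compounds alone.

In a functional assay on QGY cells (Homo sapiens) for cytotoxicity, read by MTT assay (a higher number here means a weaker inhibitor, a lower number a stronger inhibitor), compound 1 `CCOC(=O)C12C(=O)OCC=C1COC2c1ccc(F)cc1` gives > 1000000 nM, which is a limit of the assay and not a number. Compound 2 `CCOC(=O)C12C(=O)OCC=C1COC2c1ccc(N(C)C)cc1` gives > 1000000 nM in this assay, again only a limit. Compound 3 `CCOC(=O)C12C(=O)OCC=C1COC2c1ccc([N+](=O)[O-])cc1` gives > 1000000 nM in this assay, also a limit. The steps a step that the two limits leave unreadable from compound 1 to compound 2, a step that the two limits leave unreadable from compound 1 to compound 3 and a step that the two limits leave unreadable from compound 2 to compound 3 therefore cannot be sized, since all three values sit at the limit of > 1000000 nM in this assay, at which 3 of the 3 values shown sit. Compound 1 thus stands at that limit together with the other two, and no order among them can be read.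

Compound 4 `CCOC(=O)C12C(=O)OCC=C1COC2c1ccccn1` differs from compound 1 by pyridin-2-yl in place of 4-fluorophenyl on a saturated ring carbon. Every measured step exchanges one group on the aromatic ring of compound 1 and every one stays unreadable; none bears on exchanging the ring itself, so no size can be carried over. For compound 4 the expected value in this assay is 1000000 nM, estimated between 300000 nM and 3000000 nM, most likely reported once more as a limit. The expected step of a number no higher from compound 1 to compound 4 (the limit leaves the size open) is accordingly taken as none beyond the scatter.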

Compound 4, half-maximal inhibitory concentration: > 1000000 nM
Compound 4 was reported as a limit; the forecaster's own chance of this, stated with the estimate: 85%; the middle value lies on the limit itself.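

In this assay compound 4 gives > 1000000 nM, again only a limit, so its step from compound 1 cannot be read and all four compounds stay unordered: the limit of > 1000000 nM in this assay, at which 4 of the 4 values shown sit.

The compounds shown leave open whether any aromatic group on the shared core gives a measurable value.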